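Replacing the amide side chain of compound 2

The source may report more compounds than this note shows. Statements on the series, on what has been measured and on what is new or still open speak of the compounds shown alone.

Measured in a functional assay on MCF7 cells (Homo sapiens), read by MTT assay, with a stated time of 48 h (a higher number here means a weaker inhibitor, a lower number a stronger inhibitor), so far:
- compound 1 (`CCn1c(C(=O)NCCN)ccc1C(CC)(CC)c1ccc(OCC(=O)C(C)(C)C)c(C)c1`) at 75 nM
- compound 2 (`CCN(CC)CCNC(=O)c1ccc(C(CC)(CC)c2ccc(OCC(O)C(C)(C)C)c(C)c2)n1CC`) at 690 nM

Compound 2 stands at the higher of the two numbers. In this assay compound 2 gives 690 nM while compound 1 gives 75 nM as the lower number, and that gap lies beyond the scatter.

Compound 3 (`CCn1c(C(=O)N(C)CCC#N)ccc1C(CC)(CC)c1ccc(OCC(O)C(C)(C)C)c(C)c1`) has not yet been measured. It carries (2-cyanoethyl)(methyl)amino in place of (2-(diethylamino)ethyl)amino on a carbonyl carbon, so the change removes the diethylamino end of the chain and brings in a nitrile.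

Among the measured compounds shown here, no measured pair shows what this change does on its own, so any expectation for this assay here is loose. The expected change is a 2.2-fold higher number from compound 2 to compound 3 (0.34 log units; beyond the scatter) as a rough estimate, a small step toward a higher number and so toward a weaker inhibitor, only slightly beyond the scatter. For the measured compounds named here, a result with no real step would also fit this wide expectation. Compound 3 is estimated at 1500 nM as the expected value, with an expected range from 300 nM to 7000 nM as its limits of confidence.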

Compound 3, half-maximal inhibitory concentration: > 50000 nM
Compound 3 was reported as a limit; the forecaster's own chance of this, stated with the estimate: 10%; middle value at least 33-fold (1.52 log units) from the limit.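

Compound 3 is reported in this assay only as a limit, > 50000 nM, and not as a number. Even so, (2-cyanoethyl)(methyl)amino in place of (2-(diethylamino)ethyl)amino on a carbonyl carbon gives an at least 72-fold higher number from compound 2 to compound 3 (1.86 log units; beyond the scatter), which is the first reading of a change made at this place alone and shows that the activity of compound 2 does not carry over to every side chain there. The step gives only a lower bound on the size of the loss, and the one value that sets this bound is a limit: the limit of > 50000 nM in this assay, at which 1 of the 3 values shown sits.

The step combines three changes: the diethylamino end leaves, a nitrile enters, and a methyl takes the place of the amide hydrogen, so the compounds shown cannot say which of these accounts for the loss. A (2-cyanoethyl)amino group, which keeps the amide hydrogen, or a (2-(diethylamino)ethyl)(methyl)amino group, which keeps the diethylamino end and carries the methyl, would each separate these changes, and a (2-(dimethylamino)ethyl)amino chain would show how much the end of the chain can vary.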